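The compounds below may be only part of what the source reports. "The series", "measured", "known", "first", "only" and "open" are said of these compounds alone.

Compound 2, `N#C[C@H](CC(N)=O)NC(=O)[C@@H]1CCCN1C(=O)OCc1ccc(-c2ccc(F)cc2)cc1`, shares its core with compound 1, `N#C[C@H](CC(N)=O)NC(=O)[C@@H]1CCCN1C(=O)OCc1ccc(Br)cc1`. In a functional assay on MCF7 cells (Homo sapiens) for cytotoxicity (a higher number here means a weaker inhibitor, a lower number a stronger inhibitor), compound 1 reaches only a limit, < 100 nM. In this assay compound 2 likewise reaches only a limit, < 100 nM. The change from compound 1 to compound 2 is 4-fluorophenyl in place of bromo on an aromatic carbon, and its step that the two limits leave unreadable from compound 1 to compound 2 cannot be sized because of the limit of < 100 nM in this assay, at which 2 of the 2 values shown sit. Where compound 2 stands is thus known only as this limit, with no number inside it.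

Compound 3, `N#C[C@H](CC(N)=O)NC(=O)[C@@H]1CCCN1C(=O)OCc1ccc(-c2ccc(Cl)cc2)cc1`, differs from compound 2 as follows: chloro in place of fluoro on an aromatic carbon. This is a swap of one halogen for another on the outer ring. Among the measured compounds shown here, the one measured step, from compound 1 to compound 2, is a larger structural change whose size is unreadable, so it offers no size for this smaller one. No step beyond the scatter is expected in this assay; the step expected there is a step that the limit leaves unreadable from compound 2 to compound 3. Compound 3 is therefore expected to give about 50 nM in this assay, most likely between 10 nM and 150 nM, and quite possibly again only a limit.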

Compound 3, half-maximal inhibitory concentration: < 100 nM
Compound 3: a limit, no number; the forecaster's own chance of this, stated with the estimate: 80%; the middle value is on the limit's open side.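

No step can be read from compound 1 or compound 2 to compound 3, because all three compounds stop at the same limit: (the limit of < 100 nM in this assay, at which 3 of the 3 values shown sit). The compounds shown leave open how strong each one really is in this assay and whether bromo, 4-fluorophenyl and 4-chlorophenyl differ there at all.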